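Aryl change on the shared core: compound 2 to compound 3

The source may report more compounds than this note shows. Statements on the series, on what has been measured and on what is new or still open speak of the compounds shown alone.

Two members of the series have numbers in a functional assay on KBVIN cells (Homo sapiens) for antiproliferative activity, read by sulforhodamine B assay, with a stated time of 3 days; on this read-out higher numbers stand for an effect only at larger amounts of compound and lower numbers for an effect already at smaller amounts. Compound 1 `CCCCc1ccc(-c2cc(=O)c3c(o2)C(CC)(CC)C(=O)C(CC)=C3O)cc1` gives 37 uM. Compound 2 `CCC1=C(O)c2c(oc(-c3cccc(C)c3)cc2=O)C(CC)(CC)C1=O` gives 3.69 uM, the lowest of the two numbers; the nearest, compound 1, is a step beyond the scatter away, so compound 2 is the more potent of the pair on this read-out. Going by the values given here, no pair of measured compounds differs in a single place, so the series offers no direct step to lean on.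

Compound 3 `CCC1=C(O)c2c(oc(-c3ccc(O)c(C)c3C)cc2=O)C(CC)(CC)C1=O` is not yet measured. It differs from compound 2 at one place: 4-hydroxy-2,3-dimethylphenyl in place of 3-methylphenyl on an aromatic carbon. The entering group brings one hydrogen-bond donor and one hydrogen-bond acceptor where none stood before.

Among the compounds with values here, with no measured step for such a change, the expectation for compound 3 in this assay is a value near that of compound 2, as a step of a 1.4-fold higher number from compound 2 to compound 3 (0.13 log units; within the scatter) that stays within the scatter, estimated at 5 uM with a range from 1.5 uM to 20 uM.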

Compound 3, concentration for half-maximal effect: 2.75 uM
Beside the measured number, compound 3's estimate is 1.8-fold (0.26 log units) above it; the range from low to high includes it.
By their numbers in this assay, from the lowest: compounds 3 and 2 (each within the scatter of the next); then compound 1.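

Going by these compounds alone, this is the first step that differs in one place: in this assay, 4-hydroxy-2,3-dimethylphenyl in place of 3-methylphenyl gives a 1.3-fold lower number from compound 2 to compound 3 (0.13 log units; within the scatter). At this aromatic carbon next to the ring oxygen, the number therefore stays within the scatter when the entering group brings a hydrogen-bond donor and acceptor to a position that had neither in compound 2. No measured property bears on this result, so the data offer no explanation for it.

The hydroxyl and the altered methyl pattern enter together, so their separate contributions remain unresolved. Also open, from the compounds shown here alone, is how an amine or a carboxylic acid on this phenyl ring would read in this assay.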